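From compound 1 to compound 4 without a starting number

A few compounds are considered here, and "the series" means these few. Any claim that something is new, unique, unknown or untested is made for them only; others in the source may bear on it.

Results in a functional assay on the whole organism (strain BALB/c) with Mus musculus as the target, with a stated time of 4 h (a higher number here means that more compound is needed for the effect, a lower number that less compound is needed), so far:
- compound 1 `CC1=C(CN2CC(C(=O)O)C2)CCc2cc(OCC3CCc4ccccc4C3)ccc21`: "not determined" (no result reported)
- compound 2 `CC1=C(CN2CC(C(=O)O)C2)CCc2cc(OCc3ccc(CC(C)C)cc3Cl)ccc21`: 0.19 mg/kg
- compound 3 `CC1=C(CN2CC(C(=O)O)C2)CCc2cc(OCc3ccc(CC(C)C)cc3C)ccc21`: 0.23 mg/kg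

Compound 1 has no place on the numbers of this assay and its entry reads "not determined" (no result reported) with no result behind it. Compound 4 `CCc1ccc(COc2ccc3c(c2)CCC(CN2CC(C(=O)O)C2)=C3C)c(OC)c1` departs from compound 1 by a single change, (4-ethyl-2-methoxyphenyl in place of 1,2,3,4-tetrahydronaphthalen-2-yl on a saturated chain carbon bound to an oxygen on an aromatic ring), with 4-ethyl-2-methoxyphenyl in place of 1,2,3,4-tetrahydronaphthalen-2-yl on a saturated chain carbon bound to an oxygen on an aromatic ring.

Within the data shown here, the only measured step is a 1.2-fold higher number from compound 2 to compound 3 (0.08 log units; within the scatter) and it lies within the scatter. That step is methyl in place of chloro on an aromatic carbon, which is a different change from the one here, so it bears on compound 4 only loosely. Compound 1 offers no number to step from, and no size or direction of step can be expected. What remains is the level of the measured pair. Compound 2 reads 0.19 mg/kg in this assay and compound 3 reads 0.23 mg/kg within the same scatter. Among the measured compounds shown here, no measured compound carries the entering group, and the range is kept wide. For compound 4 the estimated value is 0.3 mg/kg with an expected range from 0.1 mg/kg to 0.9 mg/kg in this measure.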

Compound 4, dose for half-maximal effect: 0.026 mg/kg
Beside the measured number, compound 4's estimate is 12-fold (1.06 log units) above it, outside the stated range (below it).
By their numbers in this assay, from the lowest: compound 4; then compounds 2 and 3 (each within the scatter of the next).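

Among these compounds, no step from compound 1 to compound 4 can be read in this assay: compound 1 has no number there to compare with. The compounds shown leave open what 4-ethyl-2-methoxyphenyl in place of 1,2,3,4-tetrahydronaphthalen-2-yl does to the dose needed for half-maximal effect. Nothing available bears on the level reached by compound 4.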